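The source may report more compounds than this note shows. Statements on the series, on what has been measured and on what is new or still open speak of the compounds shown alone.

In a functional assay on MC-38 cells (Mus musculus) for antiproliferative activity, read by CCK-8 assay, with a stated time of 48 h; on this read-out lower numbers stand for stronger inhibition and higher numbers for weaker inhibition:
Compound 1 `COc1ccc(/C=C\c2cc(OC)c(OC)c(OC)c2)cc1OCc1ccc(CN2CCCCC2C(=O)O)cc1`: 5400 nM
Compound 2 `COc1ccc(/C=C\c2cc(OC)c(OC)c(OC)c2)cc1OCc1ccc(CN2CC(C(=O)O)C2)cc1`: > 10000 nM, a limit of the assay

Compound 2 stands at the limit of > 10000 nM in this assay, at which 1 of the 2 values shown sits. It therefore has no exact number.

Compound 3 `COc1ccc(/C=C\c2cc(OC)c(OC)c(OC)c2)cc1OCc1ccc(CNCCN(C)C)cc1` differs from compound 2 in one place: (2-(dimethylamino)ethyl)amino in place of 3-carboxyazetidin-1-yl on a saturated chain carbon bound to an aromatic carbon. In words, (2-(dimethylamino)ethyl)amino replaces 3-carboxyazetidin-1-yl on a saturated chain carbon bound to an aromatic carbon, so the carboxy group is lost.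

Within the data shown here, the only measured step at this place is an at least 1.8-fold higher number from compound 1 to compound 2 (0.26 log units; that floor lies within the scatter). That step exchanged one carboxy-bearing group for another, so it gives no direct measure of the new group. Only a modest move towards stronger inhibition in this assay is expected, and a reading at the limit remains possible. The estimated step is an at least 2.8-fold lower number from compound 2 to compound 3 (0.45 log units; beyond the scatter). For compound 3 the expected value is 3500 nM, within an estimated range of 800 nM to 10000 nM.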

Compound 3, half-maximal inhibitory concentration: 1400 nM
Beside the measured number, compound 3's estimate is 2.5-fold (0.40 log units) above it, within the range that was stated.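

In this assay, among these compounds, both earlier compounds carry a carboxy group at this place, on a saturated chain carbon bound to an aromatic carbon, and compound 3 is the first without one; the change to (2-(dimethylamino)ethyl)amino gives a 3.9-fold lower number from compound 1 to compound 3 (0.59 log units; beyond the scatter). Measured against the other carboxy-bearing group, the change gives an at least 7.1-fold lower number from compound 2 to compound 3 (0.85 log units; beyond the scatter), and that size is only a floor. Compound 2 has no exact number, as its value is a limit of the assay: the limit of > 10000 nM in this assay, at which 1 of the 3 values shown sits.

The new group differs from both earlier ones in lacking the carboxy group and in having no ring, and the compounds shown do not separate these two changes. From the compounds shown here alone, a plain piperidin-1-yl group without the carboxy group, or a longer chain such as (3-(dimethylamino)propyl)amino, would address what remains open at this place.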